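Pyridin-2-yl to pyridin-3-yl on the shared core

A few compounds are considered here, and "the series" means these few. Any claim that something is new, unique, unknown or untested is made for them only; others in the source may bear on it.

Three measured analogues share one core bearing two 3-hydroxyphenyl groups and differ only in the third aromatic group. Compound 1 `Oc1cccc(-c2cc(-c3ccsc3)cc(-c3cccc(O)c3)n2)c1` carries thiophen-3-yl, and in a functional assay on HeLa cells (Homo sapiens) for cytotoxicity, read by CCK-8 assay (a higher number here means a weaker inhibitor, a lower number a stronger inhibitor), compound 1 gives 16600 nM. Compound 2 `Oc1cccc(-c2cc(-c3ccco3)cc(-c3cccc(O)c3)n2)c1` carries furan-2-yl; in this assay compound 2 gives 5990 nM. Compound 3 `Oc1cccc(-c2cc(-c3ccccn3)cc(-c3cccc(O)c3)n2)c1` carries pyridin-2-yl; in this assay compound 3 gives 6500 nM. The measured steps are a 2.8-fold lower number from compound 1 to compound 2 (0.44 log units; beyond the scatter), a 2.6-fold lower number from compound 1 to compound 3 (0.41 log units; beyond the scatter) and a 1.1-fold higher number from compound 2 to compound 3 (0.04 log units; within the scatter). Compound 3 thus stands with compound 2 at the lower end of the three numbers, the two within the scatter of each other, and apart from compound 1 by a modest step.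

Compound 4 `Oc1cccc(-c2cc(-c3cccnc3)cc(-c3cccc(O)c3)n2)c1` is the next member: pyridin-3-yl in place of pyridin-2-yl on an aromatic carbon. For the measured compounds named here, no measured step relocates the nitrogen within a single six-membered ring; the nearest precedents are exchanges of one heteroaryl group for another. Of these, the swap between two heteroaryl groups in a 1.1-fold higher number from compound 2 to compound 3 (0.04 log units; within the scatter) stayed within the scatter, while the two steps away from compound 1 were only modest. A step within the scatter in this assay is therefore expected, with no preferred direction. The expected step is no change at the digits printed from compound 3 to compound 4 (within the scatter). For compound 4 in this assay the estimate is 6500 nM, with a range from 3000 nM to 14000 nM.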

Compound 4, half-maximal inhibitory concentration: > 50000 nM
Compound 4 gave a limit, no number; the forecaster's own chance of this, stated with the estimate: 0%; at least 7.6-fold (0.88 log units) between middle value and limit.
By their numbers in this assay, from the lowest: compounds 2 and 3 (each within the scatter of the next); then compound 1. At a limit, above all of these: compound 4.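

Pyridin-3-yl in place of pyridin-2-yl, with the same atoms joined differently, gives an at least 7.6-fold higher number from compound 3 to compound 4 (0.88 log units; beyond the scatter) in this assay, so at the position opposite the ring nitrogen of the shared core, relocating the nitrogen within the pyridine group matters far more than the earlier heteroaryl exchange suggested (a 1.1-fold higher number from compound 2 to compound 3 (0.04 log units; within the scatter)). The same group also separates compound 4 from the other two analogues, with an at least 8.3-fold higher number from compound 2 to compound 4 (0.92 log units; beyond the scatter) and an at least 3.0-fold higher number from compound 1 to compound 4 (0.47 log units; beyond the scatter), so a six-membered aromatic ring with one nitrogen does not by itself keep the number near that of compound 3, and compound 1 no longer marks the high end of the series. The result for compound 4 is a limit and not a number, so these three steps fix only a minimum size: the limit of > 50000 nM in this assay, at which 1 of the 4 values shown sits.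

As far as these compounds go, how far the true number for compound 4 lies past that limit stays open. Nothing measured here explains the gap between the two pyridine groups. Also open, from the compounds shown here alone, is whether pyridin-4-yl, or a phenyl group carrying an amine or a carboxylic acid, would sit with compound 3 or with compound 4 at this position.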